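A few compounds are considered here, and "the series" means these few. Any claim that something is new, unique, unknown or untested is made for them only; others in the source may bear on it.

Measured so far in a functional assay on HT-29 cells (Homo sapiens) for cytotoxicity, read by sulforhodamine B assay; a lower number here means a stronger inhibitor, a higher number a weaker inhibitor:
compound 1 `C=C1[C@@H](OC(C)=O)C[C@@H]2[C@](C)(COC=O)[C@H](OC(C)=O)CC[C@@]2(C)[C@@H]1C[C@@H](Nc1ccc(O)cc1)C1=CCOC1=O` gives 13400 nM
compound 2 `C=C1[C@@H](OC(C)=O)C[C@@H]2[C@](C)(CO[Si](C)(C)C(C)(C)C)[C@H](OC(C)=O)CC[C@@]2(C)[C@@H]1C[C@@H](Nc1cccc(F)c1)C1=CCOC1=O` gives 4520 nM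
compound 3 `C=C1[C@@H](OC(C)=O)C[C@@H]2[C@](C)(CO[Si](C)(C)C(C)(C)C)[C@H](OC(C)=O)CC[C@@]2(C)[C@@H]1C[C@@H](Nc1cccc2ccccc12)C1=CCOC1=O` gives 15000 nM

Compound 3 stands highest of the three numbers; compound 1 sits within the scatter of it, while the gap to compound 2 is beyond the scatter. Compound 4 `C=C1[C@@H](OC(C)=O)C[C@@H]2[C@](C)(CO[Si](C)(C)C(C)(C)C)[C@H](OC(C)=O)CC[C@@]2(C)[C@@H]1C[C@@H](Nc1ccc(O)cc1)C1=CCOC1=O` is not yet measured and differs from compound 3 in one place: 4-hydroxyphenyl in place of naphthalen-1-yl on an amine nitrogen. Among the compounds with values here, the only measured step that bears on this is a 3.3-fold higher number from compound 2 to compound 3 (0.52 log units; beyond the scatter), in which the naphthalen-1-yl group went in and the number rose modestly. Taking it out again for a single ring is expected to lower the number. The same 4-hydroxyphenyl group is carried, with a difference elsewhere from compound 4, by compound 1, which gives 13400 nM, so the drop is expected to be modest. Compound 4 is expected near 8000 nM (range 3000 nM to 25000 nM), a step of a 1.9-fold lower number from compound 3 to compound 4 (0.27 log units; within the scatter) being expected.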

Compound 4, half-maximal inhibitory concentration: 6140 nM
Compound 4: middle estimate off by 1.3-fold (0.11 log units), on the high side; low and high end bracket the measured number.
By their numbers in this assay, from the lowest: compounds 2 and 4 (each within the scatter of the next); then compounds 1 and 3 (each within the scatter of the next).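

In this assay, a 2.4-fold lower number from compound 3 to compound 4 (0.39 log units; beyond the scatter) shows that a return to a single ring on the amine nitrogen restores the lower range, while a 1.4-fold higher number from compound 2 to compound 4 (0.13 log units; within the scatter) leaves 4-hydroxyphenyl and 3-fluorophenyl unseparated. The amine substituent is not the only place that matters: with 4-hydroxyphenyl held constant, a 2.2-fold lower number from compound 1 to compound 4 (0.34 log units; beyond the scatter) comes from the group of 7 heavy atoms replacing the group of 2 heavy atoms on an oxygen on a saturated carbon. No measurement at hand accounts for these steps. Going by these compounds, a free hydroxyl on that oxygen remains open, as do benzyl or 4-methoxyphenyl on the amine nitrogen.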